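The source may report more compounds than this note shows. Statements on the series, on what has been measured and on what is new or still open speak of the compounds shown alone.

Measured so far:
- compound 1, `COc1ccc(/C=C/c2cc(OC)cc(OC)c2/C=C/C(=O)Nc2cc(OC)c(OC)c(OC)c2)cc1`: 8150 nM
- compound 2, `COc1ccc(/C=C/c2cc(OC)cc(OC)c2/C=C/C(=O)N2CCN(C)CC2)cc1`: 5670 nM
- compound 3, `COc1ccc(/C=C/c2cc(OC)cc(OC)c2/C=C/C(=O)N2CCCCC2)cc1`: 9750 nM

These three compounds share one core and differ only in the group attached to the carbonyl carbon of the amide. In a functional assay on B16-F10 cells (Mus musculus) for inhibition, read by MTT assay, with a stated time of 48 h (on this read-out higher numbers stand for weaker inhibition and lower numbers for stronger inhibition), compound 2 gives the lowest of the three numbers, but its neighbours sit close: compound 1 is within the scatter, and the step of a 1.7-fold higher number from compound 2 to compound 3 (0.24 log units; within the scatter) is also within the scatter, so none of the three can be told apart on this read-out.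

Compound 4, `CCCCNC(=O)/C=C/c1c(/C=C/c2ccc(OC)cc2)cc(OC)cc1OC`, has not yet been measured. It differs from compound 2 at the same place: butylamino in place of 4-methylpiperazin-1-yl on a carbonyl carbon. Going by the values given here, the only measured step that bears on this position, a 1.7-fold higher number from compound 2 to compound 3 (0.24 log units; within the scatter), stayed within the scatter, and compound 1, which also carries a hydrogen-bond donor at the amide, sits within the scatter of compound 2 as well. The expectation is therefore a step of a 1.2-fold higher number from compound 2 to compound 4 (0.09 log units; within the scatter), no larger than the scatter, in no particular direction. Compound 4 is estimated to give 7000 nM, with a range from 3500 nM to 14000 nM.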

Compound 4, half-maximal inhibitory concentration: 2080 nM
Beside the measured number, compound 4's estimate is 3.4-fold (0.53 log units) above it; the measured number lies below the stated range.
By their numbers in this assay, from the lowest: compound 4; then compounds 2, 1 and 3 (each within the scatter of the next).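

In this assay, going by these compounds alone, the group on the carbonyl carbon now makes a readable difference, with a 2.7-fold lower number from compound 2 to compound 4 (0.44 log units; beyond the scatter) and a 4.7-fold lower number from compound 3 to compound 4 (0.67 log units; beyond the scatter) and also a 3.9-fold lower number from compound 1 to compound 4 (0.59 log units; beyond the scatter) as modest steps that the earlier compounds, all within the scatter of one another, never showed. Compound 4 is therefore the strongest of the four on this read-out, and this position does respond to the change. An amide hydrogen alone does not mark out compound 4, as compound 1 also has one yet stays close to compound 2, and no measurement here explains why the butylamino compound stands apart.

From the compounds shown here alone, whether the chain's length matters remains open, and an ethyl or hexyl chain on the amide nitrogen would test this. A branched isobutyl group, or a butyl chain ending in an amine or a carboxylic acid, would show how much change this position tolerates.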